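The compounds below may be only part of what the source reports. "The series", "measured", "known", "first", "only" and "open" are said of these compounds alone.

Measured in a functional assay on HepG2 cells (Homo sapiens) for inhibition, read by MTT assay, with a stated time of 72 h; on this read-out higher numbers stand for weaker inhibition and lower numbers for stronger inhibition:
Compound 1 `Cc1ccccc1-c1cc(C(=O)N2CCC3(CC2)CC(=O)c2nn(C(C)(C)C)cc2O3)c2ccccc2n1`: > 10000 nM
Compound 2 `CC(C)(C)n1cc2c(n1)C(=O)CC1(CCN(C(=O)c3cc(-c4ccc(F)cc4)nc4ccccc34)CC1)O2`: 2930 nM

The value of compound 1 is a limit of the assay. For the measured compounds named here, compound 2, at 2930 nM, therefore holds the only actual number so far. Compound 3 `CC(C)(C)n1cc2c(n1)C(=O)CC1(CCN(C(=O)c3cc(-c4ccc(Br)cc4)nc4ccccc34)CC1)O2` has bromo in place of fluoro on an aromatic carbon, para to a large group (bromo in place of fluoro on an aromatic carbon). Going by the values given here, the one measured step at this substituent, an at least 3.4-fold lower number from compound 1 to compound 2 (0.53 log units; beyond the scatter), exchanged 2-methylphenyl for 4-fluorophenyl, so it does not test this swap. No change beyond the scatter is therefore expected in this assay. The expected change is a 1.2-fold lower number from compound 2 to compound 3 (0.07 log units; within the scatter). For compound 3 the estimated value is 2500 nM, within a range of 900 nM to 8000 nM.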

Compound 3, half-maximal inhibitory concentration: 820 nM
Compound 3: middle estimate off by 3.0-fold (0.48 log units), on the high side; the whole stated range lies above it.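

In this assay, the identity of the halogen matters at this position, which the earlier pair could not show: bromo in place of fluoro, para to a large group, gives a 3.6-fold lower number from compound 2 to compound 3 (0.55 log units; beyond the scatter). The 4-bromophenyl group also stands well clear of 2-methylphenyl, with an at least 12-fold lower number from compound 1 to compound 3 (1.08 log units; beyond the scatter). That step rests on a limit of the assay for compound 1: the limit of > 10000 nM in this assay, at which 1 of the 3 values shown sits.

The compounds shown leave open whether chloro, iodo or a methoxy group on the same aromatic carbon would match bromo. They also leave open whether the order of fluoro and bromo holds on other cores.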